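The source may report more compounds than this note shows. Statements on the series, on what has been measured and on what is new or still open speak of the compounds shown alone.

Series notes. Compound 1 `COC(=O)CC1CCN(C[C@H]2CN(c3ccc(-n4cc(-c5ccccn5)cn4)c(F)c3)C(=O)O2)CC1` gives 224 ug/mL in an ADME assay on HEK293-A cells (Homo sapiens) for cytotoxicity, read by MTT assay, with a stated time of 48 h; on this read-out higher numbers stand for weaker inhibition and lower numbers for stronger inhibition. Compound 2 `CS(=O)(=O)NC[C@H]1CN(c2ccc(-n3cc(-c4ccccn4)cn3)c(F)c2)C(=O)O1` gives 314 ug/mL in this assay, the highest of the two numbers, with compound 1 nearest. Among the measured compounds shown here, the only measured step, a 1.4-fold higher number from compound 1 to compound 2 (0.15 log units; within the scatter), swaps the group on the saturated chain carbon and stays within the scatter. Compound 3 `CNC(=O)[C@H]1CN(c2ccc(-n3cc(-c4ccccn4)cn3)c(F)c2)C(=O)O1` differs from compound 2 by methylcarbamoyl in place of (methanesulfonamido)methyl on a saturated ring carbon. For the measured compounds named here, that change has no direct precedent here, and the one step to hand gives no ground to expect a shift beyond the scatter, so the expected step is a 1.0-fold lower number from compound 2 to compound 3 (0.02 log units; within the scatter). Compound 3 is estimated at 300 ug/mL, within 150 ug/mL to 600 ug/mL.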

Compound 3, half-maximal inhibitory concentration: 342 ug/mL
Compound 3: middle estimate off by 1.1-fold (0.06 log units), on the low side; low and high end bracket the measured number.
By their numbers in this assay, from the lowest: compounds 1, 2 and 3 (each within the scatter of the next).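

In this assay, methylcarbamoyl in place of (methanesulfonamido)methyl on the saturated ring carbon next to the ring oxygen gives a small step (a 1.1-fold higher number from compound 2 to compound 3 (0.04 log units; within the scatter)). Methylcarbamoyl in place of (4-((methoxycarbonyl)methyl)piperidin-1-yl)methyl on that carbon also stays small (a 1.5-fold higher number from compound 1 to compound 3 (0.18 log units; within the scatter)), so three quite different groups at this position show no shift beyond the scatter. No measurement offered here bears on why these numbers stay together. Open, from the compounds shown here alone, is whether a carboxylic acid or a primary amine on this carbon would move the number beyond the scatter.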